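Working notes: the step from compound 3 to compound 4

The source may report more compounds than this note shows. Statements on the series, on what has been measured and on what is new or still open speak of the compounds shown alone.

Measured in a functional assay on PC-3 cells (Homo sapiens) for inhibition, read by sulforhodamine B assay, with a stated time of 48 h; on this read-out higher numbers stand for weaker inhibition and lower numbers for stronger inhibition:
- compound 1 `O=C(Nc1ccc2c(c1)N(Cc1ccc(C(=O)NO)cc1)CC2)Nc1ccc(Cl)c(C(F)(F)F)c1`: 3100 nM
- compound 2 `O=C(Nc1ccc(C(=O)NO)cc1)Nc1ccc(Cl)c(C(F)(F)F)c1`: 3100 nM
- compound 3 `O=C(CCCC(=O)Nc1ccc(NC(=O)Nc2ccc(Cl)c(C(F)(F)F)c2)cc1)NO`: > 10000 nM

Compound 3 gives a limit and not a number: the limit of > 10000 nM in this assay, at which 1 of the 3 values shown sits. Next comes compound 4 `O=C(/C=C/c1ccc(NC(=O)Nc2ccc(Cl)c(C(F)(F)F)c2)cc1)NO`, with 2-(hydroxycarbamoyl)ethenyl in place of ((3-(hydroxycarbamoyl)propyl)carbonyl)amino on an aromatic carbon. For the measured compounds named here, the one measured step that bears on this is an at least 3.2-fold higher number from compound 2 to compound 3 (0.50 log units; beyond the scatter), which brought in the group now leaving. A move back toward the value of compound 2 at 3100 nM is therefore expected in this assay, toward a lower number and stronger inhibition. The expected step is an at least 2.5-fold lower number from compound 3 to compound 4 (0.39 log units; beyond the scatter), and it is modest in size. The estimate for compound 4 is 4000 nM, with an expected range of 1500 nM to 10000 nM.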

Compound 4, half-maximal inhibitory concentration: 1900 nM
For compound 4 the middle estimate is 2.1-fold (0.32 log units) above the measured one, and the stated range covers the measured number.
By their numbers in this assay, from the lowest: compounds 4, 1 and 2 (each within the scatter of the next). At a limit, above all of these: compound 3.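

In this assay, 2-(hydroxycarbamoyl)ethenyl on this aromatic carbon gives an at least 5.2-fold lower number from compound 3 to compound 4 (0.72 log units; beyond the scatter), so the position tolerates a hydroxycarbamoyl group carried on a short unsaturated link. Compound 3 gives only a limit, so the size of that step is a bound: the limit of > 10000 nM in this assay, at which 1 of the 4 values shown sits. Against hydroxycarbamoyl itself on the same carbon, the ethenyl link gives a 1.6-fold lower number from compound 2 to compound 4 (0.21 log units; within the scatter), so the two groups cannot be told apart here.

Open, going by these compounds, is whether a saturated ethyl link would hold this level, and whether a carboxylic acid could stand in place of the hydroxycarbamoyl group.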